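This account rests on a few compounds, and the source may have more. Where it says the series, first, only, none or still open, it means among the compounds named here.

Measured compounds and their values in an ADME assay on BHK cells (Mesocricetus auratus) for cytotoxicity, read by MTT assay, with a stated time of 96 h; a higher number here means that more compound is tolerated, a lower number that less compound is tolerated:

Compound 1, `Oc1ccc(-c2nc3cc(C(F)(F)F)ccc3[nH]2)cc1`, > 100000 nM, which is a limit of the assay rather than a number.
Compound 2, `Oc1ccc(-c2nc3cc(Cl)c(Cl)cc3[nH]2)cc1`, 29000 nM.
Compound 3, `O=[N+]([O-])c1ccc(-c2nc3cc(C(F)(F)F)ccc3[nH]2)cc1`, 18000 nM.

Among the measured compounds shown here, for compound 1 the value is a limit only, and it is the one value here that sits at the limit of > 100000 nM in this assay, at which 1 of the 3 values shown sits. Compound 2 and compound 3 give numbers that lie within the usual scatter of each other, so no order between them can be read from these data.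

For the measured compounds named here, the one step measured on both ends is the change from compound 1 to compound 3, (nitro in place of hydroxy on an aromatic carbon). It gave an at least 5.5-fold lower number from compound 1 to compound 3 (0.74 log units; beyond the scatter), and because the limit of > 100000 nM in this assay, at which 1 of the 3 values shown sits, holds for compound 1 the true size of that step is known only as a lower bound.

Compound 4, `O=[N+]([O-])c1ccc(-c2nc3cc(Cl)c(Cl)cc3[nH]2)cc1`, has not yet been measured in this assay. It differs from compound 2 by nitro in place of hydroxy on an aromatic carbon, the same change as that from compound 1 to compound 3, with the same surroundings. How the core of compound 2 differs from the core of compound 1 is not broken down here.

The expectation for compound 4 rests on compound 2 with 29000 nM and on the measured step of an at least 5.5-fold lower number from compound 1 to compound 3 (0.74 log units; beyond the scatter). Carried over to compound 2, the same change is expected to give a 5.8-fold lower number from compound 2 to compound 4 (0.76 log units; beyond the scatter). Compound 4 is therefore estimated at 5000 nM, with a likely range from 1500 nM to 15000 nM.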

Compound 4, half-maximal cytotoxic concentration: > 100000 nM
Compound 4 was reported as a limit; the forecaster's own chance of this, stated with the estimate: 5%; middle value at least 20-fold (1.30 log units) away from the limit.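

In this assay, nitro in place of hydroxy on an aromatic carbon gave an at least 3.4-fold higher number from compound 2 to compound 4 (0.53 log units; beyond the scatter), and this does not match the earlier step in direction or in size: the same change on two cores in this assay, an at least 5.5-fold lower number (0.74 log units; beyond the scatter) from compound 1 to compound 3 and an at least 3.4-fold higher number (0.53 log units; beyond the scatter) from compound 2 to compound 4, at least 19-fold (1.28 log units) apart, beyond the scatter of two such steps. This shows that, within this series, the effect of this change measured on one core cannot simply be carried over to another, since the same exchange moved the number down on one core and up on the other. Among the compounds shown here, it does not show how large either step truly is, nor does it show why the two cores part ways, as only one pair per core is available and each pair has one end reported as a limit: the limit of > 100000 nM in this assay, at which 2 of the 4 values shown sit.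

The compounds shown leave open whether the opposite outcomes belong to these two cores in general or only to the exchange of hydroxy for nitro, as no other group, such as an amine or a carboxylic acid, stands in that place on both cores. They also leave open how the pattern would run on a third core, for instance one carrying a single chlorine or a nitrile, where the same pair of groups could be compared.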